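From Phenyl to 4-Methoxyphenyl: A Cytotoxicity Estimate

A few compounds are considered here, and "the series" means these few. Any claim that something is new, unique, unknown or untested is made for them only; others in the source may bear on it.

Of the compounds shown here, two have been measured so far in an ADME assay on HPLF cells (Homo sapiens) for cytotoxicity, with a stated time of 24 h; on this read-out lower numbers stand for higher toxicity in this test and higher numbers for lower toxicity in this test. Compound 1 `O=C1/C(=C/c2ccc(F)cc2)CCC/C1=C\c1ccccc1[N+](=O)[O-]` gives 67000 nM, and compound 2 `O=C1/C(=C/c2ccccc2)CCC/C1=C\c1ccc([N+](=O)[O-])cc1` gives 282000 nM. Compound 2 therefore holds the higher of the two numbers, which means lower toxicity in this test, and the gap between them lies beyond the usual scatter. The two compounds differ in more than one place, so their gap cannot be tied to any single change.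

Compound 3 `COc1ccc(/C=C2\CCC/C(=C\c3ccc([N+](=O)[O-])cc3)C2=O)cc1` has not been measured yet. It differs from compound 2 in one place, phenyl to 4-methoxyphenyl, with methoxy in place of hydrogen on an aromatic carbon, para to a large group (methoxy in place of hydrogen on an aromatic carbon). For the measured compounds named here, no measured pair shows this change, so the expectation is uncertain. A small move towards a lower number is expected because compound 2 at 282000 nM sits at the top of the two values seen so far. The estimated change is a 1.9-fold lower number from compound 2 to compound 3 (0.27 log units; within the scatter), a step not expected to go beyond the scatter. For compound 3 the estimated value in this assay is 150000 nM, with an expected range from 50000 nM to 400000 nM.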

Compound 3, half-maximal cytotoxic concentration: > 400000 nM
Compound 3: only a limit was reported; the forecaster's own chance of this, stated with the estimate: 10%; at least 2.6-fold (0.42 log units) between middle value and limit.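

In this assay compound 3 gives > 400000 nM, and this is a limit of the assay, not a number. Methoxy in place of hydrogen, on an aromatic carbon of the six-membered ring and para to a large group, gives an at least 1.4-fold higher number from compound 2 to compound 3 (0.15 log units; that floor lies within the scatter), so this first pair offers no sign that the change raises toxicity in this test, although the floor of the step alone cannot be told apart from the scatter. The true size of the step stays unknown, and the reading ends at the top of what the assay reports: the limit of > 400000 nM in this assay, at which 1 of the 3 values shown sits.

This is the only pair that shows the change, so the compounds shown do not say whether methoxy would give a similar step on a different compound, such as compound 1, whose other groups differ. They also leave open how an amine or a carboxylic acid at the same place on the ring would read in this assay, and whether either would keep the value as high or bring it down towards the lower number of compound 1.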